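Furan-2-yl in place of 4-chlorophenyl on the shared core

The compounds below may be only part of what the source reports. "The series", "measured", "known", "first", "only" and "open" are said of these compounds alone.

Of the compounds shown here, two have been measured in a functional assay on HT-29 cells (Homo sapiens) for cytotoxicity, read by sulforhodamine B assay, with a stated time of 2 days, tested at 100 uM; on this read-out lower numbers stand for less inhibition and higher numbers for more inhibition at the one concentration tested (going by the name of the read-out). Compound 1 `O=C(Nn1c(-c2cccc([N+](=O)[O-])c2)nc2c(-c3ccco3)n[nH]c2c1=O)c1cccnc1` gives 11.7%. Compound 2 `O=C(Nn1c(-c2cccc([N+](=O)[O-])c2)nc2c(-c3ccc(Cl)cc3)n[nH]c2c1=O)c1ccccc1` gives 87.8%, the higher of the two numbers, and its distance to compound 1 lies beyond the scatter. Among the measured compounds shown here, no pair of measured compounds differs in a single place, so no measured step is at hand.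

Compound 3 `O=C(Nn1c(-c2cccc([N+](=O)[O-])c2)nc2c(-c3ccco3)n[nH]c2c1=O)c1ccccc1` is the next compound to be measured in this assay. Against compound 2 the change is furan-2-yl in place of 4-chlorophenyl on an aromatic carbon. Compound 1, which also carries furan-2-yl on its core, sits far lower on the read-out, so the step is expected to go downward and to be large, well beyond the scatter, though the exact size is open. The step of a number 52.8 percentage points lower from compound 2 to compound 3 (beyond the scatter) is expected to be a clear fall. Compound 3 is expected to give 35%, with a range from 10% to 70%.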

Compound 3, a percentage reported as inhibition, at one concentration (the size of the read-out at that concentration, not a potency): 21.2%
Compound 3: middle estimate off by 13.8 percentage points, on the high side, and the stated range covers the measured number.
By their numbers in this assay, from the lowest: compounds 1 and 3 (each within the scatter of the next); then compound 2.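

In this assay, among the compounds shown here, furan-2-yl in place of 4-chlorophenyl on the aromatic carbon of the five-membered ring gives a number 66.6 percentage points lower from compound 2 to compound 3 (beyond the scatter) and is the first single change read at this position, which shows that the read-out depends strongly on the group placed here. Phenyl in place of pyridin-3-yl on the carbonyl carbon gives a number 9.5 percentage points higher from compound 1 to compound 3 (within the scatter) and does not separate the two compounds when furan-2-yl occupies the aromatic carbon. Nothing at hand explains why the read-out follows the group at this position.

On these data alone, whether the large step belongs to the ring itself or to its chlorine stays open, and a 4-methoxyphenyl or a primary amine on the same carbon would help to tell the two apart. Also open, as far as these compounds go, is whether pyridin-3-yl and phenyl remain indistinguishable with 4-chlorophenyl on the shared core.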